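A few compounds are considered here, and "the series" means these few. Any claim that something is new, unique, unknown or untested is made for them only; others in the source may bear on it.

Of the compounds shown here, three with a shared core have been measured in a functional assay on A549 cells (Homo sapiens) for inhibition, read by MTT assay, with a stated time of 24 h; a lower number here means a stronger inhibitor, a higher number a weaker inhibitor. Compound 1 `CC1(C)[C@H]2CC[C@]1(C)N(Cc1cn(-c3ccccc3Cl)nn1)C(=O)C2`, which carries a 2-chlorophenyl group, gives 70 nM. Compound 2 `COc1ccccc1-n1cc(CN2C(=O)C[C@@H]3CC[C@@]2(C)C3(C)C)nn1`, with a methoxy group in place of that chloro, gives 350 nM. Compound 3 `Cc1ccc(-n2cc(CN3C(=O)C[C@@H]4CC[C@@]3(C)C4(C)C)nn2)cc1`, which carries a 4-methylphenyl group, gives 400 nM. Compound 2 and compound 3 sit level, with a 1.1-fold higher number from compound 2 to compound 3 (0.06 log units; within the scatter), and compound 1 is the strongest of the three.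

Compound 4 `CC1(C)[C@H]2CC[C@]1(C)N(Cc1cn(-c3ccc(Cl)cc3)nn1)C(=O)C2` keeps the core of compound 3 and changes one thing: chloro in place of methyl on an aromatic carbon, para to a large group (chloro in place of methyl on an aromatic carbon). This turns 4-methylphenyl into 4-chlorophenyl.

Among the measured compounds shown here, two measured steps bear on this change. Replacing chloro with methoxy gave a 5.0-fold higher number from compound 1 to compound 2 (0.70 log units; beyond the scatter), and replacing 2-chlorophenyl with 4-methylphenyl gave a 5.7-fold higher number from compound 1 to compound 3 (0.76 log units; beyond the scatter). For the measured compounds named here, both are modest steps away from the only chloro compound measured so far, so bringing chloro back may recover some strength. However, compound 1 is a 2-chlorophenyl compound and compound 4 a 4-chlorophenyl compound, and no measurement yet shows what that difference in position does. Only part of the gap is therefore expected to close. The expected change is a modest one towards a lower number, a 2.7-fold lower number from compound 3 to compound 4 (0.43 log units; beyond the scatter). For compound 4 the estimated value is 150 nM, with an expected range of 50 nM to 400 nM.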

Compound 4, half-maximal inhibitory concentration: 70 nM
Beside the measured number, compound 4's estimate is 2.1-fold (0.33 log units) above it, within the range that was stated.
By their numbers in this assay, from the lowest: compounds 1 and 4 (each within the scatter of the next); then compounds 2 and 3 (each within the scatter of the next).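

In this assay, chloro in place of methyl on an aromatic carbon, para to a large group, gives a 5.7-fold lower number from compound 3 to compound 4 (0.76 log units; beyond the scatter) and so shows that this position responds to the identity of the group it carries. The same 4-chlorophenyl group gives a 5.0-fold lower number from compound 2 to compound 4 (0.70 log units; beyond the scatter) and, measured against the 2-chlorophenyl group, gives no change at the digits printed from compound 1 to compound 4 (within the scatter) in this set, so the two chloro placements cannot be told apart, and both chloro compounds sit apart from the methoxy and methyl compounds, with no compound shown going against this. Nothing shown here explains why chloro and methyl differ at this position.

From the compounds shown here alone, whether other groups at this position, such as fluoro, bromo, an amine or a carboxylic acid, would match chloro stays open. Also open, going by these compounds, is how methyl and methoxy would compare if each carried the same placement, since compound 2 and compound 3 differ in both the group and its place on the ring.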